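Replacing the Aryl Group on a Tricyclic Receptor Agonist Core

The source may report more compounds than this note shows. Statements on the series, on what has been measured and on what is new or still open speak of the compounds shown alone.

Of the compounds shown here, three have been measured in a functional assay on CHO-K1 cells for agonist activity at Glucose-dependent insulinotropic receptor (Homo sapiens), read by a luciferase reporter, with a stated time of 5 h; a lower number here means that less compound is needed, a higher number that more compound is needed for the effect. Compound 1 `CC(C)c1noc(N2CCC(O)CC2)n1` gives 50.1 nM. Compound 2 `CC(C)OC(=O)N1CCC(Oc2ncnc3c2CCN3c2ccc(S(C)(=O)=O)cn2)CC1` gives 126 nM, and compound 3 `CC(C)OC(=O)N1CCC(Oc2ncnc3c2CCN3c2ccc(S(C)(=O)=O)nc2)CC1` gives 251 nM. Compound 3 therefore carries the highest number of the three. Its nearest neighbour is compound 2: the step of a 2.0-fold higher number from compound 2 to compound 3 (0.30 log units; within the scatter) lies within the scatter, so these two cannot be told apart. Compound 1 stands farther away, and that gap is beyond the scatter.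

Compound 4 `CC(C)OC(=O)N1CCC(Oc2ncnc3c2CCN3c2ccc(C#N)c(F)c2)CC1` has not yet been measured. Against compound 3, the change is 4-cyano-3-fluorophenyl in place of 6-(methylsulfonyl)pyridin-3-yl on a nitrogen on an aromatic ring in a ring. Going by the values given here, the only measured step at the same place is a 2.0-fold higher number from compound 2 to compound 3 (0.30 log units; within the scatter), which moved the ring nitrogen and the methylsulfonyl within one ring and left the number within the scatter. Among the compounds with values here, no measured step exchanges the whole heteroaryl for a cyanofluorophenyl, so there is no direct precedent for this change, and the single step at this position gives no sign of a large effect either way. The step from compound 3 to compound 4 is therefore expected to be a 1.3-fold lower number from compound 3 to compound 4 (0.10 log units; within the scatter), not beyond the scatter. Compound 4 is estimated to give 200 nM in this assay, with a likely range from 60 nM to 700 nM.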

Compound 4, half-maximal effective concentration: 398 nM
For compound 4 the middle estimate is 2.0-fold (0.30 log units) below the measured one; the range from low to high includes it.
By their numbers in this assay, from the lowest: compound 1; then compounds 2, 3 and 4 (each within the scatter of the next, the first and the last beyond it).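

In this assay, the new group shows that the aryl on this nitrogen need not be a pyridine carrying methylsulfonyl: exchanging 6-(methylsulfonyl)pyridin-3-yl for 4-cyano-3-fluorophenyl gives a 1.6-fold higher number from compound 3 to compound 4 (0.20 log units; within the scatter) and so cannot be told apart from no change, even though the ring, its hetero atom and the sulfur-bearing group are all replaced. Going by these compounds alone, measured against the other pyridine, the same exchange gives a 3.2-fold higher number from compound 2 to compound 4 (0.50 log units; beyond the scatter) and is the first step at this position to clear the scatter, though it remains modest, so compound 2 and compound 4 can be told apart while compound 3 cannot be separated from either. No measurement is available that explains these numbers.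

Because nitrile and fluorine enter together, the compounds shown leave open what each contributes, which a cyanophenyl without the fluorine or a fluorophenyl without the nitrile would separate. They also leave open how this position would respond to a plain phenyl, or to a ring carrying an amine or a carboxylic acid.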